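This account rests on a few compounds, and the source may have more. Where it says the series, first, only, none or still open, it means among the compounds named here.

Compound 1 `COc1ccc(CNC(=O)CSc2nc3ccc(NC(=O)CCl)cc3s2)cc1`: 5100 nM
Compound 2 `O=C(CSc1nc2ccc(NC(=O)CCl)cc2s1)NCc1ccc(Cl)cc1`: 4900 nM

In a functional assay on MCF7 cells (Homo sapiens) for cytotoxicity, read by MTT assay, with a stated time of 48 h (a lower number here means a stronger inhibitor, a higher number a weaker inhibitor), compound 1 gives 5100 nM, the higher of the two numbers shown, though only a step within the scatter away from compound 2, which gives 4900 nM. Among the measured compounds shown here, that step, a 1.0-fold lower number from compound 1 to compound 2 (0.02 log units; within the scatter), is the one measured change. Compound 3 `COc1ccc(CNC(=O)CSc2nc3ccc(NC(=O)c4ccccc4OC)cc3s2)cc1` differs from compound 1 by 2-methoxyphenyl in place of chloromethyl on a carbonyl carbon. For the measured compounds named here, no measured step touches this position, so nothing here anchors the direction. A modest weakening is expected, with a 1.6-fold higher number from compound 1 to compound 3 (0.20 log units; within the scatter) as the estimated step. Compound 3 is estimated at 8000 nM, within 3000 nM to 25000 nM.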

Compound 3, half-maximal inhibitory concentration: 9300 nM
The estimate for compound 3 lay 1.2-fold (0.07 log units) below the measured number; measured number inside the range.
By their numbers in this assay, from the lowest: compounds 2, 1 and 3 (each within the scatter of the next).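

In this assay, among the compounds shown here, the first change at the carbonyl carbon, 2-methoxyphenyl in place of chloromethyl, leaves the number within the scatter (a 1.8-fold higher number from compound 1 to compound 3 (0.26 log units; within the scatter)). In this one pair, then, the chloromethyl can give way to a group carrying a six-membered aromatic ring without a step beyond the scatter. Nothing available explains this result. Still open, as far as these compounds go, is whether an amine, a carboxylic acid or a longer chain on this carbonyl carbon would give a step beyond the scatter. Also open, from the compounds shown here alone, is whether the same change behaves alike with the chloro compound, compound 2.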